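Solubility of a Quinoline Series: From Furan to Phenol

The compounds below may be only part of what the source reports. "The series", "measured", "known", "first", "only" and "open" are said of these compounds alone.

Of the compounds shown here, three have been measured in a physicochemical assay for solubility, with a stated time of 18 h, at pH 7.4; a lower number here means a less soluble compound, a higher number a more soluble compound. Compound 1 `COc1ccc(F)cc1CNCCCNc1ccnc2cc(Oc3ccc(F)cc3)ccc12` gives 14500 nM in this assay. Compound 2 `Fc1ccc(Cc2ccc3c(NCCCNCc4ccco4)ccnc3c2)cc1` gives 4200 nM in this assay. Compound 3 `FC(F)(F)c1cc(-c2ccc3c(NCCCNCc4ccco4)ccnc3c2)cc(C(F)(F)F)c1` gives 32000 nM in this assay, the highest of the three numbers; its nearest neighbour is compound 1, which sits beyond the scatter below it, and compound 2 lies further still.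

The next compound, compound 4 `COc1cccc(CNCCCNc2ccnc3cc(-c4cc(C(F)(F)F)cc(C(F)(F)F)c4)ccc23)c1O`, differs from compound 3 in one place: 2-hydroxy-3-methoxyphenyl in place of furan-2-yl on a saturated chain carbon bound to an amine nitrogen. For the measured compounds named here, no pair among the measured compounds shows this same change, so the step cannot be read from a measured pair. The furan gives way to a larger ring carrying a hydroxyl and a methoxy group; the data give no direct guide to what that does here.

The step from compound 3 to compound 4 is expected to be small, a modest lowering close to the scatter, a 1.6-fold lower number from compound 3 to compound 4 (0.20 log units; within the scatter). Compound 4 is estimated to give 20000 nM in this assay, within a range from 7000 nM to 60000 nM.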

Compound 4, solubility: 32000 nM
The estimate for compound 4 lay 1.6-fold (0.20 log units) below the measured number; measured number inside the range.
By their numbers in this assay, from the lowest: compound 2; then compound 1; then compounds 3 and 4 (each within the scatter of the next).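

In this assay the change of furan-2-yl to 2-hydroxy-3-methoxyphenyl on a saturated chain carbon bound to an amine nitrogen gives no change at the digits printed from compound 3 to compound 4 (within the scatter) and provides the only step shown that can be read at this position. Here the group grows from 5 to 9 heavy atoms and gains a hydrogen-bond donor, yet the read-out holds. Nothing measured here explains why the number holds.

Still open, from the compounds shown here alone, is whether the hydroxyl or the methoxy group alone on the phenyl ring would leave the number in place, since the two enter together in this single step. Also open, going by these compounds, is how a group carrying a carboxylic acid or a second amine would read at this same position.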